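The source may hold more compounds than are shown below. What is called first, only, known or untested is meant among the compounds shown, and "the series" means these compounds.

Compound 1 `Nc1ccccc1NC(=O)c1ccc(CNc2nc(Cl)nc3c2ncn3Cc2ccccc2)cc1` gave 5.01% in a functional assay on HepG2 cells (Homo sapiens) for antiproliferative activity, read by CCK-8 assay, with a stated time of 72 h, tested at 2 uM; on this read-out lower numbers stand for a weaker effect and higher numbers for a stronger effect at the one concentration tested.
Compound 2 `CCCn1cnc2c(NCc3ccc(C(=O)Nc4ccccc4N)cc3)nc(Cl)nc21` gave 12.4% in this assay.

Among the measured compounds shown here, compound 2 holds the higher of the two numbers in this assay, with compound 1 its only neighbour. For the measured compounds named here, the one measured step, a number 7.4 percentage points higher from compound 1 to compound 2 (within the scatter), changed a group on the same aromatic nitrogen of the shared core and was small. Compound 3 `Nc1ccccc1NC(=O)c1ccc(CNc2nc(Cl)nc3c2ncn3C2CCCC2)cc1` differs from compound 2 at that nitrogen: cyclopentyl in place of propyl on an aromatic nitrogen. Going by the values given here, since the only comparable step was small, no movement beyond the scatter is expected, and the estimated step is a number 1.6 percentage points higher from compound 2 to compound 3 (within the scatter). Compound 3 is therefore estimated at 14% in this assay, in the range 2% to 30%.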

Compound 3, a percentage reported as inhibition, at one concentration (the size of the read-out at that concentration, not a potency): 54.7%
Beside the measured number, compound 3's estimate is 40.7 percentage points below it; measured number above the stated range.
By their numbers in this assay, from the lowest: compounds 1 and 2 (each within the scatter of the next); then compound 3.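

In this assay the aromatic nitrogen turns out to be sensitive to its substituent: cyclopentyl in place of propyl gives a number 42.3 percentage points higher from compound 2 to compound 3 (beyond the scatter), and cyclopentyl in place of benzyl gives a number 49.7 percentage points higher from compound 1 to compound 3 (beyond the scatter). Propyl and benzyl had stayed within the scatter of each other, so among these three groups only cyclopentyl stands apart. Nothing at hand gives a reason for this jump.

From the compounds shown here alone, whether the ring itself or its carbon count goes with the higher number remains open: a pentyl chain would separate the two. Cyclobutyl and cyclohexyl would show whether ring size matters.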